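A ring swap on compound 2

A few compounds are considered here, and "the series" means these few. Any claim that something is new, unique, unknown or untested is made for them only; others in the source may bear on it.

Compound 1 `Cn1nccc1-c1cnc(NCc2c(F)ccc3c2CCO3)c2cn[nH]c(=O)c12` gives 2000 nM
Compound 2 `CN(c1ccccc1)c1cnc(NCc2c(F)ccc3c2CCO3)n2cnnc12` gives < 2000 nM as a limit

In a physicochemical assay for solubility, read by LC-MS, in phosphate buffer, with a stated time of 24 h, at pH 7.4 (on this read-out higher numbers stand for higher solubility and lower numbers for lower solubility), compound 2 stands at a limit (< 2000 nM) and not at a true number. Compound 1 has a true number (2000 nM) but carries a different core.

Compound 3 (`O=C1CCCN1c1cnc(NCc2c(F)ccc3c2CCO3)n2cnnc12`) keeps the rest of compound 2 and changes one group: 2-oxopyrrolidin-1-yl in place of methyl(phenyl)amino on an aromatic carbon in one step. Among the measured compounds shown here, no measured pair of compounds shows a change of this kind, so any forecast rests on thin ground. A moderate rise in this assay is expected, although another result at a limit remains possible. The estimated step is upward (an at least 1.5-fold higher number from compound 2 to compound 3 (0.17 log units; that floor lies within the scatter)). For compound 3 the estimated solubility is 3000 nM (expected range 1000 nM to 15000 nM).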

Compound 3, solubility: 640000 nM
Compound 3: the middle estimate sits 210-fold (2.33 log units) below what was measured; measured number above the stated range.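

Among the compounds shown here, this is the first pair in this assay that differs in one place, and it shows that the group on this aromatic carbon can matter a great deal: 2-oxopyrrolidin-1-yl in place of methyl(phenyl)amino gives an at least 320-fold higher number from compound 2 to compound 3 (2.50 log units; beyond the scatter) in a single swap. Compound 2 gives < 2000 nM as a limit and not as a true number. The step is therefore only a floor, and its full size cannot be read, because one end of it rests on that limit: the limit of < 2000 nM in this assay, at which 1 of the 3 values shown sits.

The swap removes the six-membered aromatic ring and brings in a non-aromatic ring with an oxygen, so this pair cannot say which of these changes carries the step. A dimethylamino group on the same carbon, which has no phenyl ring, would help to separate them.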